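Working notes: the step from compound 1 to compound 4

The source may report more compounds than this note shows. Statements on the series, on what has been measured and on what is new or still open speak of the compounds shown alone.

compound 1 `Cc1c(C)c2c(c(C)c1OC(=O)CCC(=O)O)CCC(C)(C(=O)NC1CC(C)(C)N([O])C(C)(C)C1)O2`: > 300000 nM (a limit)
compound 2 `Cc1c(C)c2c(c(C)c1O)CCC(C)(C(=O)NC1CC(C)(C)N([O])C(C)(C)C1)O2`: 186000 nM
compound 3 `Cc1c(C)c2c(c(C)c1OC(=O)CCC(=O)NC1CC(C)(C)N([O])C1(C)C)CC[C@@](C)(CCC[C@H](C)CCC[C@H](C)CCCC(C)C)O2`: > 300000 nM (a limit)

In a toxicity assay on cells (Cricetulus griseus) for cytotoxicity, read by MTT assay, with a stated time of 72 h (on this read-out higher numbers stand for weaker inhibition and lower numbers for stronger inhibition), compound 1 gives only a limit, > 300000 nM, and no number. Compound 3 also gives only a limit, > 300000 nM. The series therefore shows (the limit of > 300000 nM in this assay, at which 2 of the 3 values shown sit). For the measured compounds named here, compound 2 is the only one with a number, 186000 nM.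

The change to compound 4 `Cc1c(C)c2c(c(C)c1OC(=O)CCC(=O)O)CCC(C)(C(=O)O)O2` is one oxygen atom in place of a group of 12 heavy atoms (9 carbon, 2 nitrogen, 1 oxygen; one six-membered non-aromatic ring with 1 hetero atom), on a carbonyl carbon. Going by the values given here, the only measured step, an at least 1.6-fold lower number from compound 1 to compound 2 (0.20 log units; that floor lies within the scatter), lies at another place: hydrogen in place of (2-carboxyethyl)carbonyl on an oxygen on an aromatic ring. Among the compounds with values here, no measured step touches the group on the carbonyl carbon, so the data give no direct size or direction for this change.

The expectation rests on compound 1, whose limit of > 300000 nM leaves no number to step from. No step beyond the scatter is expected in this assay. The estimated step runs a number no higher from compound 1 to compound 4 (the limit leaves the size open). For compound 4 the expected value is 300000 nM, with an estimated range of 150000 nM to 600000 nM, and a report as a limit is likely.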

Compound 4, half-maximal inhibitory concentration: > 300000 nM
Compound 4 gave a limit, no number (the forecaster's own chance of this, stated with the estimate: 75%); the middle value sits exactly at the limit.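

Compound 1 and compound 4 both give only limits in this assay, so no step between them can be read: the limit of > 300000 nM in this assay, at which 3 of the 4 values shown sit.

The compounds shown leave open what the group of 12 heavy atoms on the carbonyl carbon contributes to the read-out in this assay.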